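This account rests on a few compounds, and the source may have more. Where it says the series, first, only, none or still open, it means among the compounds named here.

Among the measured compounds shown here, compound 1, whose structure is `CC(=O)OC[C@H]1O[C@@H](CC(=O)/C=C/c2cc(Cl)cc(Cl)c2)[C@H](OC(C)=O)[C@@H](OC(C)=O)[C@@H]1OC(C)=O`, is the one member of this small set that comes with a number. For the measured compounds named here, in an ADME assay on cells (Epithelial cell, Homo sapiens) for cytotoxicity, read by MTT assay, with a stated time of 24 h (on this read-out higher numbers stand for lower toxicity in this test and lower numbers for higher toxicity in this test), compound 1 gives 32.9 nM, and it stands alone on that read-out: no step to another measured compound can be drawn from it. Two further compounds share its acetylated sugar core with a different group at the end of the unsaturated ketone chain. Compound 2, `CC(=O)OC[C@H]1O[C@@H](CC(=O)/C=C/c2ccc(OC(C)=O)cc2)[C@H](OC(C)=O)[C@@H](OC(C)=O)[C@@H]1OC(C)=O`, carries an acetylated phenol on that chain, and in this assay compound 2 gives "not determined" (no result reported). Compound 3, `COc1ccccc1/C=C/C(=O)C[C@@H]1O[C@H](COC(C)=O)[C@@H](OC(C)=O)[C@H](OC(C)=O)[C@H]1OC(C)=O`, carries a methoxy-substituted phenyl there, and in this assay compound 3 gives "not determined" (no result reported). Neither of these adds a number to compare against.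

The compound still to be tested is compound 4, `CC(=O)OC[C@H]1O[C@@H](CC(=O)/C=C/c2ccc(Cl)c(Cl)c2)[C@H](OC(C)=O)[C@@H](OC(C)=O)[C@@H]1OC(C)=O`. It keeps every atom of compound 1 and rearranges only two: 3,4-dichlorophenyl in place of 3,5-dichlorophenyl on a double-bonded chain carbon bound to a double-bonded chain carbon. Both rings carry two chlorines, and nothing in the set shows what moving one of them does to cytotoxicity. Going by the values given here, with no measured step to lean on, the expectation is a step from compound 1 to compound 4 of about none beyond the scatter, a 1.0-fold higher number from compound 1 to compound 4 (0.00 log units; within the scatter). Compound 4 is therefore estimated at 33 nM in this assay, with a range from 10 nM to 110 nM.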

Compound 4, half-maximal cytotoxic concentration: 25.8 nM
The estimate for compound 4 lay 1.3-fold (0.11 log units) above the measured number, and the stated range covers the measured number.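

In this assay, among the compounds shown here, putting 3,4-dichlorophenyl in place of 3,5-dichlorophenyl on a double-bonded chain carbon bound to a double-bonded chain carbon gives a 1.3-fold lower number from compound 1 to compound 4 (0.11 log units; within the scatter) and so provides the first measured comparison in this small set. Moving one chlorine around the ring while keeping the same atoms therefore leaves the two compounds indistinguishable in this test, and compound 4 reads as an equal of compound 1 rather than as a better or worse version of it. The compounds with numbers offer no measurement that could explain this similarity.

On these data alone, compounds 2 and 3 have no number in this test, so steps to them cannot be read, and the effect of replacing the dichlorophenyl ring with their acetylated phenol or methoxy-substituted phenyl groups remains unknown. For the compounds shown here, it is also open whether the number would hold with only one chlorine on the ring, or with an amine or a carboxylic acid there, since both dichlorophenyl compounds show only that a single rearrangement of the two chlorines makes no measurable difference.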